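Working notes: amide substituent change from compound 3 to compound 4

The source may hold more compounds than are shown below. What is called first, only, known or untested is meant among the compounds shown, and "the series" means these compounds.

Of the compounds shown here, three have been measured in a functional assay on L6 cells (Rattus norvegicus) for inhibition, read by scintillation counting, with a stated time of 3 h; on this read-out lower numbers stand for stronger inhibition and higher numbers for weaker inhibition. Compound 1 `CC(C)c1c(C(=O)NCc2ccccc2)nc(-c2ccc(F)cc2)n1CC[C@@H](O)C[C@@H](O)CC(=O)O` gives 3030 nM in this assay. Compound 2 `Cc1ccc(CNC(=O)c2nn(-c3ccc(F)cc3)c(CC[C@@H](O)C[C@@H](O)CC(=O)O)c2C(C)C)cc1`, built on a different core, gives 730 nM in this assay. Compound 3 `O=C(O)C[C@H](O)C[C@H](O)CCn1c(-c2ccc(F)cc2)nc(C(=O)NCc2ccc(F)c(F)c2)c1C1CC1` gives 2780 nM in this assay. Among the three numbers compound 3 stands second highest; its nearest neighbour is compound 1, whose number lies within the scatter of that of compound 3, so no order between the two can be claimed, while compound 2 sits furthest away with a number beyond the scatter on the lower side.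

Compound 4 `Cc1ccccc1CNC(=O)c1nc(-c2ccc(F)cc2)n(CC[C@@H](O)C[C@@H](O)CC(=O)O)c1C1CC1` has not yet been measured in this assay. It differs from compound 3 in one place: 2-methylphenyl in place of 3,4-difluorophenyl on a saturated chain carbon bound to an amide-type nitrogen. For the measured compounds named here, no pair of measured compounds shows this change on its own, so its effect is not known from the data here. Compound 1, carrying an unsubstituted benzyl group on the same amide, gives a number within the scatter of that of compound 3, which suggests that variation at this position has so far produced no step beyond the scatter.

Compound 4 is therefore expected to give a value in this assay of about 2200 nM, in a range from 800 nM to 6000 nM. The step this estimate means is a 1.3-fold lower number from compound 3 to compound 4 (0.10 log units; within the scatter), expected to lie within the scatter.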

Compound 4, half-maximal inhibitory concentration: 4850 nM
Beside the measured number, compound 4's estimate is 2.2-fold (0.34 log units) below it; low and high end bracket the measured number.
By their numbers in this assay, from the lowest: compound 2; then compounds 3, 1 and 4 (each within the scatter of the next).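

In this assay, for the compounds shown here, 2-methylphenyl in place of 3,4-difluorophenyl on a saturated chain carbon bound to an amide-type nitrogen gives a 1.7-fold higher number from compound 3 to compound 4 (0.24 log units; within the scatter), the first one-place reading at this position. Taking out both fluorines and bringing in a single methyl on the ring therefore produces no step that can be told apart from repeat measurement, so for this pair the swap leaves the read-out unresolved rather than ordered. Nothing measured on these compounds accounts for this outcome, and no separate data bear on it.

Going by these compounds, the result covers only these two substituted benzyl groups on the amide, so it remains unknown whether a basic amine or a carboxylic acid on the phenyl ring, or a 2-phenylethyl chain in place of the benzyl group, would produce a step beyond the scatter. Going by these compounds alone, no one-place step connects compound 2, at 730 nM, to the other compounds, so the structural origin of that value also remains open.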